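The source may hold more compounds than are shown below. What is called first, only, known or untested is meant among the compounds shown, and "the series" means these compounds.

Measured compounds:
compound 1 `COc1cc(-c2nc(CO[C@@H]3O[C@H](CSc4ncn[nH]4)[C@H]4OC5(CCCC5)O[C@@H]34)no2)cc(OC)c1OC` — 36000 nM
compound 2 `COc1cc(-c2nc(CO[C@@H]3O[C@H](CSc4nnc(N)s4)[C@H]4OC5(CCCC5)O[C@@H]34)no2)cc(OC)c1OC` — 38000 nM
compound 3 `CC1(C)O[C@H]2[C@H](OCc3noc(-c4ccc([N+](=O)[O-])cc4)n3)O[C@H](CSc3nnc(N)s3)[C@H]2O1` — > 100000 nM (a limit of the assay)

In a functional assay on SW1573 cells (Homo sapiens) for antiproliferative activity, read by sulforhodamine B assay, with a stated time of 48 h (on this read-out higher numbers stand for weaker inhibition of growth and lower numbers for stronger inhibition of growth), compound 1 gives 36000 nM, the lowest of the two numbers in hand. Compound 2 gives 38000 nM; the step of a 1.1-fold higher number from compound 1 to compound 2 (0.02 log units; within the scatter) lies within the scatter, so the two heteroaryl sulfides on the sugar side cannot be told apart. Compound 3 differs from compound 2 in two places, the acetal and the aryl on the shared core, and reaches only a limit, (the limit of > 100000 nM in this assay, at which 1 of the 3 values shown sits).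

Compound 4 `Clc1ccc(-c2nc(CO[C@@H]3O[C@H](CSc4ncn[nH]4)[C@H]4OC5(CCCC5)O[C@@H]34)no2)cc1` carries the change (4-chlorophenyl in place of 3,4,5-trimethoxyphenyl on an aromatic carbon). Among the measured compounds shown here, no measured step addresses the aryl on the core alone; the only aryl variation in hand, in compound 3, comes paired with a second change and ends at the limit. Compound 1 stands at 36000 nM. Compound 3 ends at a limit of the assay. The expectation for compound 4 is a number near compound 1 or somewhat higher, with a real chance of a limit. Compound 4 is estimated at 60000 nM, range 25000 nM to 150000 nM, a step of a 1.7-fold higher number from compound 1 to compound 4 (0.22 log units; within the scatter).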

Compound 4, concentration for 50% growth inhibition: 10000 nM
Estimate against measurement, compound 4: 6.0-fold (0.78 log units) above; measured number below the stated range.
By their numbers in this assay, from the lowest: compound 4; then compounds 1 and 2 (each within the scatter of the next). At a limit, above all of these: compound 3.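

In this assay, among the compounds shown here, the change to 4-chlorophenyl gives a 3.6-fold lower number from compound 1 to compound 4 (0.56 log units; beyond the scatter) and is the first single-place step to pass beyond the scatter, which the change on the sulfur did not do. This position on the shared core therefore responds to the choice of aryl group, and the 3,4,5-trimethoxyphenyl group is not needed for the activity seen so far, since the group that enters has fewer heavy atoms and no hydrogen-bond acceptors. Nothing measured in hand accounts for the size of this step.

A single pair cannot separate the loss of the methoxy groups from the entry of chlorine, and unsubstituted phenyl or 4-methoxyphenyl at this position would bear on that. Also open, from the compounds shown here alone, is whether the gain carries over to the 5-amino-1,3,4-thiadiazol-2-yl group on the sulfur.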